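This account rests on a few compounds, and the source may have more. Where it says the series, first, only, none or still open, it means among the compounds named here.

Measured compounds:
compound 1 `CNc1nc(C)c(C(=O)N/N=C/c2cccc(C(F)(F)F)c2)s1`: in a functional assay on MCF7 cells (Homo sapiens) for inhibition, read by MTT assay, with a stated time of 72 h (on this read-out lower numbers stand for stronger inhibition and higher numbers for weaker inhibition), compound 1 gives > 100 ug/mL, a limit of the assay rather than a number.
compound 2 `CNc1nc(C(F)(F)F)c(C(=O)N/N=C/c2cccc(C(F)(F)F)c2)s1`: in this assay compound 2 gives > 100 ug/mL, again only a limit.
compound 3 `Cc1nc(N(C)C(=O)NC(=O)c2c(F)cccc2F)sc1C(=O)N/N=C/c1ccccc1C(F)(F)F`: in this assay compound 3 gives 7.34 ug/mL.

Compound 2 therefore stands at the limit of this assay, together with compound 1 (the limit of > 100 ug/mL in this assay, at which 2 of the 3 values shown sit), so its own inhibitory strength is not pinned down. Among the measured compounds shown here, the only step between measured compounds, a step that the two limits leave unreadable from compound 1 to compound 2, is unreadable because both ends are limits, and it changes a different part of the molecule anyway.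

Compound 4 `CN(C(=O)NC(=O)c1ccccc1F)c1nc(C(F)(F)F)c(C(=O)N/N=C/c2cccc(C(F)(F)F)c2)s1` is built from compound 2 by ((2-fluorophenyl)carbonyl)carbamoyl in place of hydrogen on a nitrogen on an aromatic ring. For the measured compounds named here, no measured step follows this change directly. Going by the values given here, compound 3, which carries a related group on its ring nitrogen, is the one measured compound with a number, and its value sits well inside the assay range, while compound 2 does not; no step between them is given, so only that contrast can be read.

On that basis compound 4 is expected to leave the limit and reach 12 ug/mL, with a likely range of 3 ug/mL to 50 ug/mL. The step of an at least 8.3-fold lower number from compound 2 to compound 4 (0.92 log units; beyond the scatter) is thus estimated to be a clear gain in inhibition, though its size remains uncertain.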

Compound 4, half-maximal inhibitory concentration: 20.5 ug/mL
Compound 4: the middle estimate sits 1.7-fold (0.23 log units) below what was measured, and the stated range covers the measured number.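

Putting ((2-fluorophenyl)carbonyl)carbamoyl in place of hydrogen on the nitrogen on an aromatic ring gives, in this assay, an at least 4.8-fold lower number from compound 2 to compound 4 (0.68 log units; beyond the scatter). Among the compounds shown here, this is the first readable step, and since a lower number here means stronger inhibition, it shows that this nitrogen can carry a group of this size and that the change lifts the compound off the assay limit and into the measurable range. The printed size is only a minimum rather than an exact difference, because compound 2 has no number of its own: the limit of > 100 ug/mL in this assay, at which 2 of the 4 values shown sit.

The compounds shown do not reveal which part of the new group matters, so a smaller acetyl group, or a benzoyl-carbamoyl group without the fluorine, could give a similar or a quite different result on that nitrogen. They also leave open whether the same group would produce a comparable step on compound 1, which carries methyl where compound 2 carries trifluoromethyl.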